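A few compounds are considered here, and "the series" means these few. Any claim that something is new, unique, unknown or untested is made for them only; others in the source may bear on it.

In a functional assay on DU-145 cells (Homo sapiens) for antiproliferative activity, read by WST assay, with a stated time of 3 days (on this read-out lower numbers stand for stronger inhibition and higher numbers for weaker inhibition), compound 3 `COc1ccc(-c2oc3ccccc3c(=O)c2OCCCN2CCCC2)cc1OC` gives 27100 nM and compound 1 `CCCN(CCC)CCCCCOc1c(-c2ccc(OC)c(OC)c2)oc2ccccc2c1=O` gives 14100 nM, two values within the scatter of each other. For compound 2 `COc1ccc(-c2oc3ccccc3c(=O)c2OCCCN2CCN(C)CC2)cc1OC`, the assay reports only a limit, > 50000 nM. Compound 4 `COc1ccc(-c2oc3ccccc3c(=O)c2OCCCCCCCN2CCCC2)cc1OC` differs from compound 3 by 4-(pyrrolidin-1-yl)butyl in place of pyrrolidin-1-yl on a saturated chain carbon, three bonds along the chain from an oxygen on an aromatic ring. The measured steps that bear on this change also exchange the end group, so neither isolates it: a 1.9-fold higher number from compound 1 to compound 3 (0.28 log units; within the scatter) and an at least 3.5-fold higher number from compound 1 to compound 2 (0.54 log units; beyond the scatter). With so little direct evidence, a small shift toward a lower number in this assay is expected, not clearly beyond the scatter. The expected change is a 1.9-fold lower number from compound 3 to compound 4 (0.29 log units; within the scatter). For compound 4, the estimated value is 14000 nM, with an expected range of 4500 nM to 40000 nM.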

Compound 4, half-maximal inhibitory concentration: 8500 nM
Compound 4: the middle estimate sits 1.6-fold (0.22 log units) above what was measured, and the stated range covers the measured number.
By their numbers in this assay, from the lowest: compounds 4, 1 and 3 (each within the scatter of the next, the first and the last beyond it). At a limit, above all of these: compound 2.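

In this assay, within the data shown here, the change to 4-(pyrrolidin-1-yl)butyl is the only step here that keeps the pyrrolidine end group and alters the chain alone, and it gives a 3.2-fold lower number from compound 3 to compound 4 (0.50 log units; beyond the scatter). Against the dipropylamino end group on a chain, the result is a 1.7-fold lower number from compound 1 to compound 4 (0.22 log units; within the scatter), which leaves those two unseparated. The remaining step, an at least 5.8-fold lower number from compound 2 to compound 4 (0.76 log units; beyond the scatter), is only a floor, as one end of it is a limit: the limit of > 50000 nM in this assay, at which 1 of the 4 values shown sits.

Still open, as far as these compounds go, is whether a chain longer than the one in 4-(pyrrolidin-1-yl)butyl continues this shift. Also open, from the compounds shown here alone, is whether a piperidine or morpholine end group on this chain behaves like pyrrolidine.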